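Cyclohexyl for aryl on the amine of the quinone series

The compounds below may be only part of what the source reports. "The series", "measured", "known", "first", "only" and "open" are said of these compounds alone.

Compound 3 `O=C1C=C(Nc2ccc(C(F)(F)F)cc2)C(=O)c2c1nc1n2[C@H]2OC[C@@H](O)[C@H]2OC1` gives 2820 nM in a functional assay on MGC-803 cells (Homo sapiens) for inhibition, read by sulforhodamine B assay (a higher number here means a weaker inhibitor, a lower number a stronger inhibitor), the highest of the three numbers; compound 2 `O=C1C=C(NCc2ccccc2)C(=O)c2c1nc1n2[C@H]2OC[C@@H](O)[C@H]2OC1` gives 2670 nM, within the scatter of it, whereas compound 1 `Cc1ccc(NC2=CC(=O)c3nc4n(c3C2=O)[C@H]2OC[C@@H](O)[C@H]2OC4)cc1C` gives 860 nM, beyond the scatter. The steps of a 3.1-fold higher number from compound 1 to compound 2 (0.49 log units; beyond the scatter) and a 3.3-fold higher number from compound 1 to compound 3 (0.52 log units; beyond the scatter) are modest, while a 1.1-fold higher number from compound 2 to compound 3 (0.02 log units; within the scatter) lies within the scatter. Compound 4 `O=C1C=C(NC2CCCCC2)C(=O)c2c1nc1n2[C@H]2OC[C@@H](O)[C@H]2OC1` differs from compound 3 by cyclohexyl in place of 4-(trifluoromethyl)phenyl on an amine nitrogen. Among the measured compounds shown here, no measured step exchanges an aromatic for a non-aromatic ring, so the only guide is a 1.1-fold higher number from compound 2 to compound 3 (0.02 log units; within the scatter), which suggests that varying this substituent moves the number little. Compound 4 is therefore expected at 2500 nM, with a range of 1000 nM to 7000 nM. The expected step of a 1.1-fold lower number from compound 3 to compound 4 (0.05 log units; within the scatter) is not beyond the scatter.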

Compound 4, half-maximal inhibitory concentration: > 8000 nM
Compound 4: only a limit was reported; the forecaster's own chance of this, stated with the estimate: 5%; at least 3.2-fold (0.50 log units) between middle value and limit.
By their numbers in this assay, from the lowest: compound 1; then compounds 2 and 3 (each within the scatter of the next). At a limit, above all of these: compound 4.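

In this assay the reading for compound 4 is a limit and not a number: the limit of > 8000 nM in this assay, at which 1 of the 4 values shown sits.
Cyclohexyl is the only group shown on this amine nitrogen that has no aromatic ring, and each exchange for it raises the number beyond the scatter: an at least 2.8-fold higher number from compound 3 to compound 4 (0.45 log units; beyond the scatter), an at least 2.9-fold higher number from compound 2 to compound 4 (0.47 log units; beyond the scatter) and an at least 9.3-fold higher number from compound 1 to compound 4 (0.96 log units; beyond the scatter).
This position is therefore less indifferent to its substituent than the benzyl and 4-(trifluoromethyl)phenyl pair suggested.

As far as these compounds go, how far compound 4 lies past its limit stays open. A single cyclohexyl cannot show whether the missing aromatic ring is what counts; a piperidine, a cyclohexylmethyl group or a straight hexyl chain on this nitrogen would test that.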